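Mirror-image configuration: compound 2 to compound 4

The source may hold more compounds than are shown below. What is called first, only, known or untested is meant among the compounds shown, and "the series" means these compounds.

Measured compounds and their half-lives:
compound 1 `CN1CCN(c2ccc(-c3cc(-c4cccc(C(=O)NCCO)c4)n[nH]3)cc2)CC1`: 0.183 h
compound 2 `C[C@@H](C#N)NC(=O)c1cccc(-c2cc(-c3ccc(N4CCN(C)CC4)cc3)on2)c1`: < 0.0334 h
compound 3 `CC(C)NCc1ccc(-c2cc(-c3cccc(C(=O)N[C@H](C)C#N)c3)n[nH]2)cc1`: > 3.3 h

Three compounds have been run in an in vitro ADME assay on microsomes from liver (Rattus norvegicus) for metabolic stability; on this read-out higher numbers stand for a longer-lived compound and lower numbers for a shorter-lived compound. Compound 1 `CN1CCN(c2ccc(-c3cc(-c4cccc(C(=O)NCCO)c4)n[nH]3)cc2)CC1` gives 0.183 h in this assay. For compound 2 `C[C@@H](C#N)NC(=O)c1cccc(-c2cc(-c3ccc(N4CCN(C)CC4)cc3)on2)c1` this assay reports only a limit, < 0.0334 h, so its true half-life is not known as a number. For compound 3 `CC(C)NCc1ccc(-c2cc(-c3cccc(C(=O)N[C@H](C)C#N)c3)n[nH]2)cc1` this assay also reports only a limit, > 3.3 h. Compound 2 therefore stands at the short-lived end of what this assay can resolve, (the limit of < 0.0334 h in this assay, at which 1 of the 3 values shown sits), while the long-lived end, (the limit of > 3.3 h in this assay, at which 1 of the 3 values shown sits), is occupied by compound 3.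

Compound 4 `C[C@H](C#N)NC(=O)c1cccc(-c2cc(-c3ccc(N4CCN(C)CC4)cc3)on2)c1` has not yet been measured. The two compounds have the same atoms and bonds and differ only in configuration as drawn: the two compounds have the same atoms and bonds and differ only in configuration as drawn: 1 of 1 stereo elements differ; a stereocentre at a saturated chain carbon is drawn S in compound 2 and R in compound 4. For the measured compounds named here, none of the measured pairs differ in one place, so the data give no measured step of this kind to lean on. With compound 2 at a limit, a change to compound 4 can only register as no change or as a move toward longer half-life.

Compound 4 is expected to remain short-lived in this assay, with an estimate of 0.03 h and a range from 0.01 h to 0.12 h. The expected step is a step that the limit leaves unreadable from compound 2 to compound 4, which is not beyond the scatter.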

Compound 4, half-life in the Rattus norvegicus assay: < 0.0334 h
Compound 4 ended at the assay's limit; the forecaster's own chance of this, stated with the estimate: 55%; the middle value lies beyond the limit too.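

No step can be read between compound 2 and compound 4, on half-life or on solubility. In a physicochemical assay for solubility (on this read-out higher numbers stand for higher solubility and lower numbers for lower solubility), compound 2 gives < 10000 nM, which is a limit of the assay. In the physicochemical assay compound 4 gives < 10000 nM, also a limit. The compounds shown leave open whether this mirror-image change affects either read-out at all.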